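A few compounds are considered here, and "the series" means these few. Any claim that something is new, unique, unknown or untested is made for them only; others in the source may bear on it.

Measured so far:
compound 1 `OC1CN(CCCOc2ccccc2)CCc2cc(OCc3ccccc3)ccc21` gives 193 nM
compound 2 `O=S(=O)(CCCN1CCc2cc(OCc3ccccc3)ccc2C(O)C1)c1ccccc1` gives 349 nM

The two numbers come from an assay for displacement of a labelled ligand from Sigma non-opioid intracellular receptor 1 (Cavia porcellus), read by scintillation counting, with a stated time of 180 min; on this read-out higher numbers stand for weaker inhibition and lower numbers for stronger inhibition. Compound 1 and compound 2 lie within the scatter of each other, as a 1.8-fold higher number from compound 1 to compound 2 (0.26 log units; within the scatter) shows; compound 1 therefore cannot be set apart from compound 2 on these numbers. That single step exchanges phenylsulfonyl for phenoxy on a saturated chain carbon, three bonds along the chain from an amine nitrogen in a ring, and leaves the rest of the chain in place.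

Compound 3 `OC1CN(C2CCC3(CC2)OCCO3)CCc2cc(OCc3ccccc3)ccc21` goes further. Its difference from compound 1 is a group of 10 heavy atoms (8 carbon, 2 oxygen; one five-membered non-aromatic ring with 2 hetero atoms, one six-membered non-aromatic ring of carbon only) in place of a group of 10 heavy atoms (9 carbon, 1 oxygen; one six-membered aromatic ring of carbon only), on an amine nitrogen in a ring: the whole 3-phenoxypropyl chain is gone and a spiro-fused pair of non-aromatic rings sits directly on the amine nitrogen. Going by the values given here, no measured step covers a change of this kind, so the one known step can only show that the far end of the chain tolerates one exchange without a shift beyond the scatter. The expectation for compound 3 in this assay is a modest rise, a 2.1-fold higher number from compound 1 to compound 3 (0.32 log units; beyond the scatter), with wide uncertainty. Compound 3 is estimated at 400 nM, within 100 nM to 1600 nM.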

Compound 3, inhibition constant: 183 nM
For compound 3 the middle estimate is 2.2-fold (0.34 log units) above the measured one, within the range that was stated.
By their numbers in this assay, from the lowest: compounds 3, 1 and 2 (each within the scatter of the next).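

In this assay the exchange on the amine nitrogen in a ring replaces the whole 3-phenoxypropyl group rather than one link of its chain, yet it comes out as a 1.1-fold lower number from compound 1 to compound 3 (0.02 log units; within the scatter). For these compounds, then, a number in this range does not depend on the chain or on the six-membered aromatic ring of carbon only that leaves with it: the entering group, with its five-membered non-aromatic ring with 2 hetero atoms and its six-membered non-aromatic ring of carbon only, serves equally well on these numbers, so this position accepts two groups of the same heavy-atom count but very different shape. Nothing at hand gives a reason for this agreement.

From the compounds shown here alone, whether the agreement depends on group size remains open, as a methyl group or a much longer chain on the same nitrogen could read quite differently from a group of this heavy-atom count. Going by these compounds, it is also open whether a carboxylic acid at the end of the chain would be accepted, or how a carbonyl would compare with the hydroxy group on the shared core.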